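A few compounds are considered here, and "the series" means these few. Any claim that something is new, unique, unknown or untested is made for them only; others in the source may bear on it.

Measured so far in a functional assay on KB cells (Homo sapiens) for cytotoxicity; on this read-out higher numbers stand for weaker inhibition and lower numbers for stronger inhibition:
- compound 1 `COc1ccc(S(=O)(=O)N2CCc3cccc(NC(=O)C(C)(C)C)c32)cc1`: 359 nM
- compound 2 `COc1ccc(S(=O)(=O)N2CCc3cccc(NS(=O)(=O)c4ccc(F)cc4)c32)cc1`: 1200 nM
- compound 3 `COc1ccc(S(=O)(=O)N2CCc3cccc(N)c32)cc1`: 2800 nM

All three compounds share one core and differ only in what sits on a nitrogen on an aromatic ring. Compound 3 carries just hydrogen there, and at 2800 nM compound 3 has the highest number of the three, making it the weakest so far.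

The next compound is compound 4 `COc1ccc(C(=O)Nc2cccc3c2N(S(=O)(=O)c2ccc(OC)cc2)CC3)cc1`. It has (4-methoxyphenyl)carbonyl in place of hydrogen on a nitrogen on an aromatic ring.

Within the data shown here, two measured steps bear on this change. With (tert-butyl)carbonyl on that nitrogen, the data show a 7.8-fold higher number from compound 1 to compound 3 (0.89 log units; beyond the scatter). With (4-fluorophenyl)sulfonyl there, they show a 2.3-fold higher number from compound 2 to compound 3 (0.37 log units; beyond the scatter). In both cases, losing the group raises the number, and neither of the two substituted compounds goes against this. Among the measured compounds shown here, compound 4 resembles compound 1 in carrying a carbonyl on that nitrogen, so compound 1 is the closer guide, although no compound with this exact group has been measured.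

A move to a lower number is therefore expected, estimated as a 9.3-fold lower number from compound 3 to compound 4 (0.97 log units; beyond the scatter). For compound 4, the expected value is 300 nM, with an estimated range from 60 nM to 1400 nM.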

Compound 4, half-maximal inhibitory concentration: 2600 nM
The estimate for compound 4 lay 8.7-fold (0.94 log units) below the measured number; measured number outside the range, above it.
By their numbers in this assay, from the lowest: compound 1; then compound 2; then compounds 4 and 3 (each within the scatter of the next).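

In this assay, among these compounds, a carbonyl on this nitrogen does not lower the number by itself: (4-methoxyphenyl)carbonyl in place of hydrogen gives a 1.1-fold lower number from compound 3 to compound 4 (0.03 log units; within the scatter) and so no real change, whereas the earlier compounds had suggested a clear drop. What is attached to the carbonyl carbon decides the outcome, as 4-methoxyphenyl in place of tert-butyl gives a 7.2-fold higher number from compound 1 to compound 4 (0.86 log units; beyond the scatter) and the low number of compound 1 therefore cannot be credited to the carbonyl alone; (4-methoxyphenyl)carbonyl in place of (4-fluorophenyl)sulfonyl gives a 2.2-fold higher number from compound 2 to compound 4 (0.34 log units; beyond the scatter) and so also places this amide on the weaker side of the sulfonyl compound. No measurement available here explains why these groups behave so differently.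

Compound 4 alone cannot show whether the higher number goes with the ring or with its methoxy group, and an unsubstituted phenyl, a cyclohexyl or a methyl on the carbonyl carbon would help separate these possibilities. Also open, going by these compounds, is how far the tert-butyl result extends, for example to an isopropyl group or to a longer chain ending in an amine.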